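The compounds below may be only part of what the source reports. "The series", "measured", "known", "first", "only" and "open" are said of these compounds alone.

Measured so far:
- compound 1, `CC(C)(C)c1ccc(S(=O)(=O)Nc2ccc(Cl)cc2-c2ncccc2CO)cc1`: 89 nM
- compound 2, `CC(C)(C)c1ccc(S(=O)(=O)Nc2ccc(Cl)cc2-c2ncccc2CN)cc1`: 3160 nM
- compound 3, `CC(C)(C)c1ccc(S(=O)(=O)Nc2ccc(Cl)cc2-c2nccc(CO)c2O)cc1`: 8.7 nM

In a functional assay on isolated protein for antagonist activity at C-C chemokine receptor type 9 (Homo sapiens), read by calcium flux, with a stated time of 10 min (a lower number here means a stronger inhibitor, a higher number a weaker inhibitor), compound 3 gives the lowest number of the three. Its nearest neighbour is compound 1, with a 10-fold lower number from compound 1 to compound 3 (1.01 log units; beyond the scatter), and the furthest is compound 2, with a 360-fold lower number from compound 2 to compound 3 (2.56 log units; beyond the scatter). The step to compound 4, `CN(C)c1ncnc(-c2cc(Cl)ccc2NS(=O)(=O)c2ccc(C(C)(C)C)cc2)c1O`, is a group of 10 heavy atoms (6 carbon, 3 nitrogen, 1 oxygen; one six-membered aromatic ring with 2 hetero atoms) in place of a group of 9 heavy atoms (6 carbon, 1 nitrogen, 2 oxygen; one six-membered aromatic ring with 1 hetero atom), on an aromatic carbon. The hydroxy on the ring is kept, the hydroxymethyl is removed, and a dimethylamino and a second ring nitrogen enter. Among the measured compounds shown here, no measured step matches this directly. For the measured compounds named here, two steps bear on it: from compound 1 to compound 3 the ring hydroxy was added, with a 10-fold lower number from compound 1 to compound 3 (1.01 log units; beyond the scatter); from compound 1 to compound 2 the hydroxy on the chain was exchanged for amino, with a 36-fold higher number from compound 1 to compound 2 (1.55 log units; beyond the scatter), showing that the hydroxymethyl matters. Because compound 3 gives 8.7 nM and loses that group here while keeping the ring hydroxy, a moderate rise is expected, estimated as a 6.9-fold higher number from compound 3 to compound 4 (0.84 log units; beyond the scatter), giving for compound 4 an expected 60 nM within 10 nM to 400 nM.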

Compound 4, half-maximal inhibitory concentration: 9 nM
Compound 4: middle estimate off by 6.7-fold (0.82 log units), on the high side; the measured number lies below the stated range.
By their numbers in this assay, from the lowest: compounds 3 and 4 (each within the scatter of the next); then compound 1; then compound 2.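

In this assay, a compound without the hydroxymethyl can match one that has it: exchanging that group for a dimethylamino and a second ring nitrogen, with the ring hydroxy kept, gives a 1.0-fold higher number from compound 3 to compound 4 (0.01 log units; within the scatter). The heavy cost seen earlier when amino replaced the chain hydroxy therefore does not extend to this replacement, and the new group also compares well with the two compounds lacking a ring hydroxy, with a 9.9-fold lower number from compound 1 to compound 4 (1.00 log units; beyond the scatter) and a 350-fold lower number from compound 2 to compound 4 (2.55 log units; beyond the scatter). Nothing available explains why this exchange leaves the two compounds within the usual scatter of each other.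

From the compounds shown here alone, the hydroxymethyl left while the dimethylamino and the second ring nitrogen entered together, so what each contributes alone remains open. Going by these compounds, how a primary amine or a carboxylic acid would read in place of the dimethylamino also remains open.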